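The compounds below may be only part of what the source reports. "The series", "measured", "known", "first", "only" and "open" are said of these compounds alone.

Compound 2, `Cc1cc(C)cc(Cc2ccc3c(NCCCNCc4ccco4)ccnc3c2)c1`, stands in a physicochemical assay for acid dissociation, at 9.47. It sits level with its two measured neighbours. Compound 1, `COc1ccc(F)cc1CNCCCNc1ccnc2cc(Cc3cc(C)cc(C)c3)ccc12`, gives 9.47, and the step of no change at the digits printed from compound 1 to compound 2 (within the scatter) shows that exchanging furan-2-yl for 5-fluoro-2-methoxyphenyl on the saturated chain carbon bound to an amine nitrogen leaves the read-out where it was. Compound 3, `CCC(CC)c1ccc2c(NCCCNCc3cc(F)ccc3OC)ccnc2c1`, gives 9.47, and the step of no change at the digits printed from compound 1 to compound 3 (within the scatter) shows the same for pentan-3-yl in place of 3,5-dimethylbenzyl on an aromatic carbon. Compound 2 therefore lies no further from compound 3 than from compound 1 at the digits recorded.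

Compound 4, `c1coc(CNCCCNc2ccnc3cc(C4CCCCC4)ccc23)c1`, carries the change (cyclohexyl in place of 3,5-dimethylbenzyl on an aromatic carbon). Going by the values given here, the step that bears most directly on it is the one from compound 1 to compound 3, where a different saturated group replaced 3,5-dimethylbenzyl on the same aromatic carbon and the read-out did not move beyond the scatter. The proton that is measured sits on the amine side of the molecule, which compound 4 shares with compound 2. No movement beyond the scatter is expected in this assay. Compound 4 is expected to give 9.47, within a range from 9.2 to 9.75. That corresponds to an expected step of no change at the digits printed from compound 2 to compound 4 (within the scatter).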

Compound 4, acid dissociation constant: 9.47
Estimate against measurement, compound 4: no gap at the digits printed; the measured number falls inside the stated range.
By their numbers in this assay, from the lowest: compounds 1, 2, 3 and 4 (each within the scatter of the next).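

In this assay the exchange of 3,5-dimethylbenzyl for cyclohexyl on this aromatic carbon gives no change at the digits printed from compound 2 to compound 4 (within the scatter) and so leaves the read-out where it was with furan-2-yl on the amine side of the molecule, whereas the earlier step at this carbon, no change at the digits printed from compound 1 to compound 3 (within the scatter) for pentan-3-yl, had 5-fluoro-2-methoxyphenyl on that side. Going by these compounds alone, the position has now taken a second saturated group, this time a six-membered non-aromatic ring of carbon only with 6 heavy atoms against the 9 of the group it replaces, and neither exchange at this carbon among compounds 1, 2, 3 and 4 has moved the number beyond the scatter, with no compound going against that. Nothing at hand accounts for this flat result, so no reason can be offered for it.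

On these data alone, whether the read-out would hold with an amine or a carboxylic acid on this aromatic carbon stays open, as the groups seen there so far are all of carbon and hydrogen only. Also open is the effect of a longer chain linking the core to the amine nitrogen, a part of the molecule that none of the steps shown has touched.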